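The source may report more compounds than this note shows. Statements on the series, on what has been measured and on what is new or still open speak of the compounds shown alone.

Working notes on the series, read in a physicochemical assay for solubility, at pH 1.1; on this read-out lower numbers stand for lower solubility and higher numbers for higher solubility. Compound 1 `Cc1cc(CN(CC2CC2)C(CC(=O)O)c2ccc(Cl)cc2)ccc1OCCN1C(=O)CCC1=O` gives 3000000 nM, and compound 2 `Cc1cc(CN(CC2CC2)[C@@H](CC(=O)O)c2ccc(Cl)cc2)ccc1OCCN1C(=O)CCC1=O` gives 3000000 nM, so the two stand level at the digits shown. Among the compounds with values here, the only measured step, no change at the digits printed from compound 1 to compound 2 (within the scatter), comes down to the fact that one of compounds 1 and 2 is drawn with a defined configuration and the other without, at the place where they differ. That step leaves the group on the amine nitrogen untouched, so it offers no size for the next change and serves only to show that the level holds across the two drawings.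

Compound 3 `Cc1cc(CN(CCC(F)(F)F)C(CC(=O)O)c2ccc(Cl)cc2)ccc1OCCN1C(=O)CCC1=O` differs from compound 1 as follows: 2,2,2-trifluoroethyl in place of cyclopropyl on a saturated chain carbon bound to an amine nitrogen. Within the data shown here, no measured compound carries 2,2,2-trifluoroethyl, so the only anchor is compound 1 at 3000000 nM. The expected step, a 1.2-fold lower number from compound 1 to compound 3 (0.08 log units; within the scatter), is no real move in either direction beyond the scatter. For compound 3 the estimated value is 2500000 nM, with an expected range of 1000000 nM to 3500000 nM.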

Compound 3, solubility: 3000000 nM
The estimate for compound 3 lay 1.2-fold (0.08 log units) below the measured number, and the stated range covers the measured number.
By their numbers in this assay, from the lowest: compounds 1, 2 and 3 (each within the scatter of the next).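

In this assay the change on a saturated chain carbon bound to an amine nitrogen, 2,2,2-trifluoroethyl in place of cyclopropyl, reads no change at the digits printed from compound 1 to compound 3 (within the scatter) and is the only change of this group shown. Where the earlier pair left this group untouched, the level now holds across a change of the group itself: the three-membered ring leaves, and 5 heavy atoms, three of them fluorine, stand in place of 3 carbon atoms. Nothing on record bears on this change, so the shared level remains without an explanation.

Still open, as far as these compounds go, is whether the level would hold with an amine or a carboxylic acid at this position, or with a longer chain. Also open, from the compounds shown here alone, is whether compound 3 would read the same when drawn with a defined configuration.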